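Dropping the iodophenyl amide for a plain chain

The compounds below may be only part of what the source reports. "The series", "measured", "known", "first", "only" and "open" are said of these compounds alone.

Compound 1, `Cn1c(Cc2nn(C)c(=O)c3ccccc23)nnc1SCCCCCCCC(=O)Nc1ccc(Cl)cc1Cl`, in an assay on isolated protein (Mus musculus) for inhibition of IL15-IL15 receptor (Homo sapiens), read by resazurin assay, with stated times of 30 min and 2.5 days (a higher number here means a weaker inhibitor, a lower number a stronger inhibitor), gives 1900 nM.
Compound 2, `Cn1c(Cc2nn(C)c(=O)c3ccccc23)nnc1SCCCCCCCC(=O)Nc1ccc(Br)cc1Br`, in this assay gives 1500 nM.
Compound 3, `Cn1c(Cc2nn(C)c(=O)c3ccccc23)nnc1SCC(=O)Nc1ccc(I)cc1`, in this assay gives "not active" (no number reported), with no number.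

Compound 3 therefore stands without a value to compare. The step to compound 4, `CCCCCCCCCCSc1nnc(Cc2nn(C)c(=O)c3ccccc23)n1C`, puts (nonyl in place of (4-iodophenyl)carbamoyl on a saturated chain carbon bound to a sulfur). Within the data shown here, the one measured step, a 1.3-fold lower number from compound 1 to compound 2 (0.10 log units; within the scatter), swaps one dihalophenyl for another while keeping the amide, so it says little about removing the carbamoyl altogether; no measured step does that. Compound 1 and compound 2 keep an amide on a long chain and give numbers, whereas compound 3, with a short chain, gives none. Because compound 1 gives 1900 nM with a long chain, compound 4, which also has a long chain but lacks the amide, is expected to be similar or weaker. Compound 4 is estimated at 3000 nM, between 600 nM and 30000 nM.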

Compound 4, half-maximal inhibitory concentration: 7600 nM
Beside the measured number, compound 4's estimate is 2.5-fold (0.40 log units) below it, and the stated range covers the measured number.
By their numbers in this assay, from the lowest: compounds 2 and 1 (each within the scatter of the next); then compound 4.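

With the chain otherwise kept, putting propyl in place of the dihalophenyl carbamoyl groups raises the number in this assay (both a 5.1-fold higher number from compound 2 to compound 4 (0.70 log units; beyond the scatter) and a 4.0-fold higher number from compound 1 to compound 4 (0.60 log units; beyond the scatter)). So the amide with its halogenated ring is not needed for a measurable value, but the two compounds carrying it give the lower numbers, which the swap between the two dihalophenyl groups could not show. Nothing measured here explains the difference.

The step from compound 3 to compound 4 cannot be read, as compound 3 has no number. Going by these compounds, whether a carboxylic acid or an amine in place of the propyl would recover the lower numbers remains open.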